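The compounds below may be only part of what the source reports. "The series", "measured", "known", "first", "only" and "open" are said of these compounds alone.

Measured so far:
- compound 1, `N/C(=N\NC(=S)N1CCCCC1)c1ccccn1`: 88.5%
- compound 2, `Cc1cccc(/C(N)=N/NC(=S)N2CCOCC2)n1`: 83.8%

In a functional assay on A-375 cells (Homo sapiens) for cytotoxicity, read by MTT assay, with a stated time of 72 h, tested at 100 uM (on this read-out lower numbers stand for less inhibition of growth and higher numbers for more inhibition of growth at the one concentration tested), compound 1 gives 88.5%, and compound 2 gives 83.8%. Compound 2 therefore stands at one of two numbers that lie within the usual scatter of each other, so no order between compound 1 and compound 2 can be claimed from this assay.

Compound 3, `Cc1cccc(/C(N)=N/NC(=S)N2CCCCC2)n1`, is not yet measured. It differs from compound 2 in one place: piperidin-1-yl in place of morpholin-4-yl on a thiocarbonyl carbon. Compound 1 already carries this piperidin-1-yl group, though on a core without the methyl group, and compound 1 gives 88.5% in this assay. Among the compounds with values here, no measured pair isolates this change, so the expectation rests on compound 1 and compound 2 alone. The step from compound 2 to compound 3 is expected to be small, a number 3.2 percentage points higher from compound 2 to compound 3 (within the scatter), not beyond the scatter. For compound 3 the estimate in this assay is 87%, within 76% to 95%.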

Compound 3, percent growth inhibition at one concentration: 85.7%
Estimate against measurement, compound 3: 1.3 percentage points above; the measured number falls inside the stated range.
By their numbers in this assay, from the lowest: compounds 2, 3 and 1 (each within the scatter of the next).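

In this assay, within the data shown here, piperidin-1-yl in place of morpholin-4-yl on a thiocarbonyl carbon comes to a number 1.9 percentage points higher from compound 2 to compound 3 (within the scatter), the first direct reading of this change, and it shows no difference that can be told from scatter on the core that carries the methyl group. The same compound also isolates methyl in place of hydrogen on an aromatic carbon, which comes to a number 2.8 percentage points lower from compound 1 to compound 3 (within the scatter), so this change also has no readable effect here. Both single changes therefore leave the growth inhibition at one tested concentration without a claimable order.

As far as these compounds go, whether an open-chain dimethylamino group or piperazin-1-yl on the thiocarbonyl carbon, or chlorine in place of the methyl, would move the number remains open. Nothing further at hand bears on these results.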